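A few compounds are considered here, and "the series" means these few. Any claim that something is new, unique, unknown or untested is made for them only; others in the source may bear on it.

Measured so far, in a functional assay on A549 cells (Homo sapiens) for antiproliferative activity, read by MTT assay, with a stated time of 72 h; on this read-out higher numbers stand for weaker inhibition and lower numbers for stronger inhibition: compound 1 `O=C(Nc1ccccc1Cl)C(Cl)Cl` gives 50200 nM; compound 2 `O=C(Nc1ccccc1Br)C(Cl)Cl` gives 37000 nM; compound 3 `O=C(Nc1cccc(Cl)c1)C(Cl)Cl` gives 14800 nM.

Compound 3 stands at the lowest of the three numbers, and its gaps to compound 1 and compound 2 are given as beyond the scatter. How the core of compound 3 differs from the core of compound 1 is not broken down here. Between compound 1 and compound 2 the change is bromo in place of chloro on an aromatic carbon, and it made a step of a 1.4-fold lower number from compound 1 to compound 2 (0.13 log units; within the scatter).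

Compound 4 `O=C(Nc1cccc(Br)c1)C(Cl)Cl` has not yet been measured in this assay. It arises from compound 3 by bromo in place of chloro on an aromatic carbon, the same kind of change, though here the place is meta rather than ortho to the group of 6 heavy atoms. Because the earlier step of a 1.4-fold lower number from compound 1 to compound 2 (0.13 log units; within the scatter) lay within the scatter, a step of about a 1.2-fold lower number from compound 3 to compound 4 (0.09 log units; within the scatter) is expected here too. For compound 4, the value is estimated at 12000 nM, between 6000 nM and 25000 nM.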

Compound 4, half-maximal inhibitory concentration: 7800 nM
Estimate against measurement, compound 4: 1.5-fold (0.19 log units) above, within the range that was stated.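

In this assay, bromo in place of chloro on an aromatic carbon gave a 1.9-fold lower number from compound 3 to compound 4 (0.28 log units; within the scatter). Set beside the earlier step, the same change shows no difference that can be told apart between the two cores: the same change on two cores in this assay, a 1.4-fold lower number (0.13 log units; within the scatter) from compound 1 to compound 2 and a 1.9-fold lower number (0.28 log units; within the scatter) from compound 3 to compound 4, 1.4-fold (0.15 log units) apart, within the scatter of two such steps. For the compounds shown here, this shows only that the change behaved alike on these two cores; it does not show that bromo and chloro can be told apart on either core, and two pairs say nothing about any other core.

The compounds shown leave open what other groups on the aromatic ring, such as a methoxy group, a nitrile or an amine, would give in this assay. They also leave open what a longer chain or a carboxylic acid would give in place of the group of 6 heavy atoms.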